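Bromo to Methyl: Expected Cytotoxicity of Compound 4

The source may report more compounds than this note shows. Statements on the series, on what has been measured and on what is new or still open speak of the compounds shown alone.

Compound 1 `Cc1ccc(C2CC(c3ccc(C)c(C)c3)=NN2C2=NC(=O)CS2)cc1`: 384000 nM
Compound 2 `Cc1ccc(C2=NN(C3=NC(=O)CS3)C(c3ccc(Br)cc3)C2)cc1C`: 365000 nM
Compound 3 `O=C1CSC(N2N=C(c3ccc(Cl)c(Cl)c3)CC2c2ccc(Br)cc2)=N1`: 280000 nM

These three compounds were tested in an ADME assay on RAW264.7 cells (Mus musculus) for cytotoxicity, read by MTT assay, with a stated time of 24 h; on this read-out higher numbers stand for lower toxicity in this test and lower numbers for higher toxicity in this test. Compound 2 and compound 3 carry the same 4-bromophenyl group and differ in the core: 3,4-dichlorophenyl in place of 3,4-dimethylphenyl on a carbon with a double bond to nitrogen. That change gave a 1.3-fold lower number from compound 2 to compound 3 (0.12 log units; within the scatter). Compound 1 differs from compound 2 by methyl in place of bromo on an aromatic carbon, a step of a 1.1-fold higher number from compound 2 to compound 1 (0.02 log units; within the scatter). Compound 4 `Cc1ccc(C2CC(c3ccc(Cl)c(Cl)c3)=NN2C2=NC(=O)CS2)cc1` has not yet been measured; it differs from compound 3 by methyl in place of bromo on an aromatic carbon, the same change as between compound 2 and compound 1, with the place described in identical words. Compound 4 is therefore expected to show a step of a 1.1-fold higher number from compound 3 to compound 4 (0.03 log units; within the scatter) from compound 3, because the same change earlier gave a 1.1-fold higher number from compound 2 to compound 1 (0.02 log units; within the scatter). Compound 4 is estimated at 300000 nM, most likely between 150000 nM and 600000 nM.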

Compound 4, half-maximal cytotoxic concentration: 279000 nM
The estimate for compound 4 lay 1.1-fold (0.03 log units) above the measured number, within the range that was stated.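

In this assay, putting methyl in place of bromo gave a 1.0-fold lower number from compound 3 to compound 4 (0.00 log units; within the scatter), which matches the same change on the other core: the same change on two cores in this assay, a 1.1-fold higher number (0.02 log units; within the scatter) from compound 2 to compound 1 and a 1.0-fold lower number (0.00 log units; within the scatter) from compound 3 to compound 4, 1.1-fold (0.02 log units) apart, within the scatter of two such steps. Putting 3,4-dichlorophenyl in place of 3,4-dimethylphenyl gave a 1.4-fold lower number from compound 1 to compound 4 (0.14 log units; within the scatter), and this also matches its earlier counterpart: the same change on two cores in this assay, a 1.3-fold lower number (0.12 log units; within the scatter) from compound 2 to compound 3 and a 1.4-fold lower number (0.14 log units; within the scatter) from compound 1 to compound 4, 1.1-fold (0.02 log units) apart, within the scatter of two such steps. Within the data shown here, both changes therefore behaved alike on the two cores, but since every step lies within the scatter, this shows only that neither change produced a measurable shift here, not that a change with a clear effect would carry over equally well.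

The compounds shown carry only bromo, methyl and chloro groups on their aromatic rings. On these data alone, whether an amine or a carboxylic acid on an aromatic carbon would shift the number, and whether that shift would carry between cores, remains open.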